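The source may hold more compounds than are shown below. What is called first, only, known or untested is meant among the compounds shown, and "the series" means these compounds.

Of the compounds shown here, two have so far been measured in a functional assay on RS4-11 cells (Homo sapiens) for inhibition, read by CCK-8 assay, with a stated time of 48 h; a lower number here means a stronger inhibitor, a higher number a weaker inhibitor. Compound 1 `O=C(NCCNS(=O)(=O)c1ccc(-c2ccccc2O[C@H]2CC[C@@H](O)CC2)s1)Nc1cc(C(F)(F)F)cc(C(F)(F)F)c1` gives 9300 nM in this assay, and compound 2 `Cc1ccc(-c2ccsc2S(=O)(=O)NCCNC(=O)Nc2ccc([N+](=O)[O-])cc2)c(Oc2ccc(O)c(O)c2)c1` gives 7700 nM. Compound 1 holds the higher of these two numbers, but the gap to compound 2 lies within the scatter of repeated measurements, so the two cannot be told apart on these data. Compound 3 `Nc1ccc(Oc2ccccc2-c2ccc(S(=O)(=O)NCCNC(=O)Nc3cc(C(F)(F)F)cc(C(F)(F)F)c3)s2)cc1` is a variant of compound 1 that has not yet been measured: 4-aminophenyl in place of 4-hydroxycyclohexyl on an oxygen on an aromatic ring. The group that leaves contains one six-membered non-aromatic ring of carbon only with two defined stereocentres, while the group that enters contains one six-membered aromatic ring of carbon only. Among the measured compounds shown here, no measured pair shows a change of this kind, so nothing fixes the size of the step. The change is expected to give only a modest step in this assay, a 1.4-fold lower number from compound 1 to compound 3 (0.16 log units; within the scatter), not clearly beyond the scatter in either direction. Compound 3 is therefore estimated at 6500 nM, with a range from 1800 nM to 24000 nM.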

Compound 3, half-maximal inhibitory concentration: 11900 nM
Estimate against measurement, compound 3: 1.8-fold (0.26 log units) below; measured number inside the range.
By their numbers in this assay, from the lowest: compounds 2, 1 and 3 (each within the scatter of the next).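

Putting 4-aminophenyl in place of 4-hydroxycyclohexyl on this oxygen gives, in this assay, a 1.3-fold higher number from compound 1 to compound 3 (0.11 log units; within the scatter), the first step read at this position. So, for this one pair on the core of compound 1, a non-aromatic ring carrying a hydroxyl and an aromatic ring carrying an amine cannot be told apart, although the swap also removes the defined stereocentres and keeps the counts of heavy atoms, donors and acceptors unchanged. No measured property bears on why the two groups read alike.

Ring type and ring substituent change together here, so their separate contributions remain unknown. On these data alone, it also remains open whether a much smaller group on this oxygen, such as methyl, or a phenyl ring carrying a carboxylic acid, would move the number beyond the scatter.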